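Nitrooxy alkanoyl esters of the shared core: chain length

The compounds below may be only part of what the source reports. "The series", "measured", "known", "first", "only" and "open" are said of these compounds alone.

Measured so far in a functional assay on aorta (Rattus norvegicus, strain Wistar), in the presence of a further agent that is not named here; on this read-out higher numbers stand for an effect only at larger amounts of compound and lower numbers for an effect already at smaller amounts:
compound 1 `O=C(CCCO[N+](=O)[O-])Oc1ccccc1C(=O)O`: 23000 nM
compound 2 `O=C(CCO[N+](=O)[O-])Oc1ccccc1C(=O)O`: 37000 nM
compound 3 `O=C(CC(CO[N+](=O)[O-])O[N+](=O)[O-])Oc1ccccc1C(=O)O`: 9200 nM

Compound 1 has the second highest of the three numbers. Its nearest neighbour is compound 2, with a 1.6-fold higher number from compound 1 to compound 2 (0.21 log units; within the scatter), a step within the scatter; its furthest is compound 3, with a 2.5-fold lower number from compound 1 to compound 3 (0.40 log units; beyond the scatter), a modest step beyond the scatter. Compound 3 also stands apart from compound 2 by a 4.0-fold lower number from compound 2 to compound 3 (0.60 log units; beyond the scatter).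

Compound 4 `O=C(CCCCCCO[N+](=O)[O-])Oc1ccccc1C(=O)O` carries the change (3-(nitrooxy)propyl in place of nitrooxy on a saturated chain carbon, three bonds along the chain from a carbonyl carbon). For the measured compounds named here, the only measured step that bears on the length of the chain is the one from compound 1 to compound 2, which shortened the chain and stayed within the scatter. The two steps into compound 3 add a second nitrooxy group and say nothing about chain length. Lengthening the chain is therefore expected to give no step beyond the scatter in this assay. The expected step is a 1.3-fold lower number from compound 1 to compound 4 (0.11 log units; within the scatter). The estimate for compound 4 is 18000 nM, with a range from 6000 nM to 50000 nM.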

Compound 4, half-maximal effective concentration: 8100 nM
For compound 4 the middle estimate is 2.2-fold (0.35 log units) above the measured one; the measured number falls inside the stated range.
By their numbers in this assay, from the lowest: compounds 4 and 3 (each within the scatter of the next); then compounds 1 and 2 (each within the scatter of the next).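

In this assay, 3-(nitrooxy)propyl in place of nitrooxy on a saturated chain carbon, three bonds along the chain from a carbonyl carbon, gives a 2.8-fold lower number from compound 1 to compound 4 (0.45 log units; beyond the scatter). This position therefore responds to chain length when the chain is lengthened, which the shortening step, a 1.6-fold higher number from compound 1 to compound 2 (0.21 log units; within the scatter), did not show. Adding a second nitrooxy group, as in compound 3, is thus not the only change in the series to give a step beyond the scatter, and no measurement at hand accounts for the step to compound 4.

Still open, from the compounds shown here alone, is whether a longer chain than that of compound 4 would lower the number further or reverse the step. Also open, going by these compounds, is how an amine or a carboxylic acid in place of nitrooxy on the longer chain would read out.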